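The source may hold more compounds than are shown below. What is called first, only, known or untested is meant among the compounds shown, and "the series" means these compounds.

Working notes on the series in a functional assay on HCT-116 cells (Homo sapiens) for inhibition, read by MTT assay, with a stated time of 48 h; a higher number here means a weaker inhibitor, a lower number a stronger inhibitor. Compound 2 `COc1ccc(CN(C(=O)C=C(C)C)c2cc(OC)c(OC)c(OC)c2)cc1O` gives 290 nM in this assay, the lowest of the two numbers shown; the nearest is compound 1 `COc1ccc(CNc2cc(OC)c(OC)c(OC)c2)cc1[N+](=O)[O-]`, which gives 18200 nM, a gap beyond the scatter. Compound 3 `COc1cc(NCc2ccc(Br)cc2)cc(OC)c1OC` gives only a limit of the assay, > 80000 nM, and sits at the limit of > 80000 nM in this assay, at which 1 of the 3 values shown sits. Within the data shown here, no pair of measured compounds differs in one place, so no measured step bears directly on the change ahead. Compound 4 `C=CC(=O)N(Cc1ccc(OC)c(O)c1)c1cc(OC)c(OC)c(OC)c1` differs from compound 2 in one place: vinyl in place of 2-methylprop-1-en-1-yl on a carbonyl carbon. The change on the carbonyl carbon, whose other neighbour is the amide-type nitrogen, is expected to give a small step, a 1.5-fold lower number from compound 2 to compound 4 (0.16 log units; within the scatter), close to the scatter. For compound 4 the estimate in this assay is 200 nM, with a range from 60 nM to 700 nM.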

Compound 4, half-maximal inhibitory concentration: 98 nM
Compound 4: middle estimate off by 2.0-fold (0.31 log units), on the high side; the range from low to high includes it.
By their numbers in this assay, from the lowest: compound 4; then compound 2; then compound 1. At a limit, above all of these: compound 3.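

Among these compounds, on the carbonyl carbon whose other neighbour is the amide-type nitrogen, this assay gives the first readable step at this position: vinyl in place of 2-methylprop-1-en-1-yl gives a 3.0-fold lower number from compound 2 to compound 4 (0.47 log units; beyond the scatter), a modest change. The earlier compounds shown here differ in more than one place, so they could not show that the group with 2 heavy atoms serves better here than the one with 4.

Nothing measured here gives a cause for this step. Going by these compounds, whether an ethyl group, a longer chain or an aminomethyl group on the same carbonyl carbon would extend or reverse the step stays open.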